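Adding a Methyl to the Core of Compound 2

The compounds below may be only part of what the source reports. "The series", "measured", "known", "first", "only" and "open" are said of these compounds alone.

Measured so far:
Compound 1, `Cc1cnc(-c2ccccc2C(C)C)nc1NCc1ccc(-c2cccnc2)cc1`, in an assay on a protein complex for inhibition of ubiquitin carboxyl-terminal hydrolase 1/WD repeat-containing protein 48 (Homo sapiens), read by fluorescence; a higher number here means a weaker inhibitor, a lower number a stronger inhibitor: 70 nM
Compound 2, `Cc1cc(NCc2ccc(-c3cccnc3)cc2)nc(-c2ccccc2C(C)C)n1`, in this assay: 210 nM

Among these two numbers, compound 2 stands at the higher one, the weaker end. Compound 1 gives the lower number, and the gap between compound 2 and compound 1 is beyond the usual scatter of repeated measurements.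

Compound 3, `Cc1nc(-c2ccccc2C(C)C)nc(NCc2ccc(-c3cccnc3)cc2)c1C`, has not yet been measured in this assay. It differs from compound 2 in one place: methyl in place of hydrogen on an aromatic carbon, that is, a methyl in place of hydrogen on an aromatic carbon. Going by the values given here, no pair of measured compounds shows a change of this kind, so there is no measured step to lean on. The expected size of this step is a 1.1-fold lower number from compound 2 to compound 3 (0.02 log units; within the scatter), with no clear direction, within the usual scatter. Compound 3 is expected to give about 200 nM in this assay, with an estimated range from 60 nM to 650 nM.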

Compound 3, half-maximal inhibitory concentration: 120 nM
Beside the measured number, compound 3's estimate is 1.7-fold (0.22 log units) above it; measured number inside the range.
By their numbers in this assay, from the lowest: compounds 1, 3 and 2 (each within the scatter of the next, the first and the last beyond it).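

In this assay, the step of a 1.8-fold lower number from compound 2 to compound 3 (0.24 log units; within the scatter) shows that a methyl can stand on this aromatic carbon, ortho to a methyl group, without a change that rises above the scatter. The step of a 1.7-fold higher number from compound 1 to compound 3 (0.23 log units; within the scatter) is also a methyl in place of hydrogen on an aromatic carbon, and it too stays within the scatter. Compound 3 carries both methyl groups, and its number cannot be separated from that of compound 1 or that of compound 2, even though those two stand apart from each other beyond the scatter.

Going by these compounds, whether a larger group at this position, such as an ethyl chain, an amine or a carboxylic acid, would keep the number in this range stays open. Nothing available explains why these numbers fall where they do.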